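A Fluorophenyl Swap in a Non-Toxic Series

The compounds below may be only part of what the source reports. "The series", "measured", "known", "first", "only" and "open" are said of these compounds alone.

Of the compounds shown here, three have been tested in a toxicity assay on HepG2 cells (Homo sapiens) for inhibition, read by CellTiter-Glo, with a stated time of 48 h; on this read-out higher numbers stand for weaker inhibition and lower numbers for stronger inhibition. Compound 1 `Cc1cc(C)cc(NC(=O)COc2cc(C)nc3ccc(C(F)(F)F)cc23)c1` gives > 100000 nM, which is a limit of the assay rather than a number. Compound 2 `COc1ccc2nc(C)cc(NC(=O)C(=O)Nc3cc(C)cc(C)c3)c2c1` gives > 100000 nM, also a limit. Compound 3 `COc1ccc2nc(C)cc(OCC(=O)Nc3cc(C)ccc3C)c2c1` gives > 100000 nM, again a limit. Among the compounds with values here, compound 3 thus stands where every value so far stands, at the limit of > 100000 nM in this assay, at which 3 of the 3 values shown sit. Compound 4 `COc1ccc2nc(C)cc(OCC(=O)Nc3ccc(F)cc3)c2c1` differs from compound 3 by one exchange: 4-fluorophenyl in place of 2,5-dimethylphenyl on an amide-type nitrogen. Within the data shown here, no measured pair in this assay differs in only one place, so the size of such a change is unknown here. With all three measured compounds at the limit, the step expected in this assay is a step that the limit leaves unreadable from compound 3 to compound 4, none beyond the scatter. Compound 4 is therefore estimated at 120000 nM, within 50000 nM to 400000 nM, most likely reported again only as a limit.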

Compound 4, half-maximal inhibitory concentration: 63100 nM
The estimate for compound 4 lay 1.9-fold (0.28 log units) above the measured number; the measured number falls inside the stated range.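

In this assay, 4-fluorophenyl in place of 2,5-dimethylphenyl on the amide-type nitrogen gives an at least 1.5-fold lower number from compound 3 to compound 4 (0.19 log units; that floor lies within the scatter). Within the data shown here, compound 4 is the first compound here to give a measured number, 63100 nM. The others remain where they stood: the limit of > 100000 nM in this assay, at which 3 of the 4 values shown sit. On these data alone, the true size of the step remains unknown, but this site can bring the read-out within measurable range.

As far as these compounds go, it remains open whether the fluorine or the loss of the two methyl groups matters. A plain phenyl on the same nitrogen would separate the two.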